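The source may hold more compounds than are shown below. What is called first, only, known or untested is meant among the compounds shown, and "the series" means these compounds.

Compound 1 `NC1=NC2(CCSCC2)N(OCCCOc2cccc(Cl)c2)C(N)=N1` and compound 2 `NC1=NC2(CCSCC2)N(OCCCOc2ccccc2Br)C(N)=N1` share one core and differ only in the halogen-bearing ring that hangs from the oxygen on the saturated chain. In an assay on isolated protein for inhibition of Dihydrofolate reductase (Homo sapiens), read by spectrophotometry, using NADPH, with stated times of 5 s and 6 min, tested at 5 uM (a higher number here means a stronger effect of the compound at the concentration tested, a lower number a weaker effect), compound 1 gives 88.3%, and in this assay compound 2 gives 88.7%. The change between them, a number 0.4 percentage points higher from compound 1 to compound 2 (within the scatter), is too small to separate the two, so compound 2 cannot be placed above or below compound 1 on these numbers; the two simply sit together at a strongly inhibiting level.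

Compound 3 `NC1=NC2(CCSCC2)N(OCCCOc2ccccc2Cl)C(N)=N1` is not yet measured. It differs from compound 2 by chloro in place of bromo on an aromatic carbon. Within the data shown here, no measured step swaps one halogen for another at the same place on the ring, so the single step from compound 1 to compound 2 is the only guide, and that step, which moved both the kind of halogen and its position, stayed within the scatter. On that basis the step of a number 1.7 percentage points lower from compound 2 to compound 3 (within the scatter) is expected to be small, with no clear direction beyond the scatter. Compound 3 is therefore estimated at 87% in this assay, with a likely range from 78% to 94%.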

Compound 3, a percentage reported as inhibition, at one concentration (the size of the read-out at that concentration, not a potency): 86.3%
Compound 3: the middle estimate sits 0.7 percentage points above what was measured; the measured number falls inside the stated range.
By their numbers in this assay, from the lowest: compounds 3, 1 and 2 (each within the scatter of the next).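

With compound 3, a change of halogen can be read on its own at a single place on the ring: in this assay, chloro in place of bromo on an aromatic carbon, ortho to a large group, gives a number 2.4 percentage points lower from compound 2 to compound 3 (within the scatter), so at this place the two halogens cannot be told apart. A change in the position of the chlorine can now also be read on its own. In the first pair, both the halogen and its position changed. Here, 2-chlorophenyl in place of 3-chlorophenyl gives a number 2 percentage points lower from compound 1 to compound 3 (within the scatter), and these two positions cannot be told apart either. No independent measurement is available to explain these results.

A percentage at one concentration is not a potency, so these numbers leave open whether the three compounds would still match at a lower concentration. As far as these compounds go, it also remains open whether a group of a different kind on the ring in place of the halogen, such as an amine or a carboxylic acid, or a longer chain on the oxygen, would give a step beyond the scatter.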